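The source may report more compounds than this note shows. Statements on the series, on what has been measured and on what is new or still open speak of the compounds shown alone.

Series notes, whole-animal paw edema set. Compound 1 `Sc1nnc(COc2ccc(-c3ccccc3)cc2)n1-c1ccc(Cl)cc1` gives 18.2% in a functional assay on the whole organism (strain Wistar) for inhibition, with Rattus norvegicus as the target, read by paw edema, with a stated time of 4 h, at a dose of 10 mg/kg by the oral route; a higher number here means more inhibition at the dose given (going by the name of the read-out), a lower number less inhibition. Compound 2 `Sc1nnc(COc2ccc(-c3ccccc3)cc2)n1-c1ccc(Br)cc1` gives 31.8% in this assay. Compound 3 `CCCCNc1nnc(COc2ccc(-c3ccccc3)cc2)s1` gives 27.3% in this assay and stands second highest of the three values; its gaps to compound 2 and to compound 1 are both within the scatter. Going by the values given here, the one measured step, bromo in place of chloro on an aromatic carbon, reads a number 13.6 percentage points higher from compound 1 to compound 2 (beyond the scatter). Compound 4 `Clc1ccc(Nc2nnc(COc3ccc(-c4ccccc4)cc3)s2)cc1` is not yet measured; the change from compound 3 is 4-chlorophenyl in place of butyl on a nitrogen on an aromatic ring. Among the compounds with values here, no measured step touches the group on the nitrogen, so the halogen step is only a loose guide, suggesting a modest shift at most. The expected step is a number 2.7 percentage points higher from compound 3 to compound 4 (within the scatter) for compound 4. Compound 4 is estimated at 30%, range 15% to 45%.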

Compound 4, a percentage reported as inhibition, in the whole organism at one dose (the size of the read-out at that dose, not a potency): 54.5%
Compound 4: the middle estimate sits 24.5 percentage points below what was measured; the measured number lies above the stated range.
By their numbers in this assay, from the lowest: compounds 1, 3 and 2 (each within the scatter of the next, the first and the last beyond it); then compound 4.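

The group on the nitrogen on an aromatic ring is a place where the read-out responds: 4-chlorophenyl in place of butyl gives a number 27.2 percentage points higher from compound 3 to compound 4 (beyond the scatter) in this assay at this dose. At this position an aromatic ring carrying chlorine is compatible with inhibition, and the butyl chain is not required for it. Nothing at hand explains the step.

Going by these compounds, it remains open whether the ring or its chlorine accounts for the step; phenyl and 4-bromophenyl on that nitrogen would separate the two. On these data alone, how a benzyl group or a longer chain would read there is also open.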